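A few compounds are considered here, and "the series" means these few. Any claim that something is new, unique, unknown or untested is made for them only; others in the source may bear on it.

Compounds measured so far:
- compound 1, `CCOc1ccc(Cc2nnc(CN(c3cccc(Cl)c3C)S(=O)(=O)c3ccc(C)cc3)o2)cc1`: 3.98 nM
- compound 2, `Cc1ccc(S(=O)(=O)N(Cc2nnc(Cc3ccc(F)cc3)o2)c2cccc(Cl)c2C)cc1`: 200 nM
- compound 3, `Cc1ccc(S(=O)(=O)N(Cc2nnc(Cc3cccc(F)c3)o2)c2cccc(Cl)c2C)cc1`: 316 nM

The read-out throughout is an assay on CHO cells for displacement of a labelled ligand from prostaglandin E2 receptor EP1 subtype (Homo sapiens); on this read-out lower numbers stand for stronger inhibition and higher numbers for weaker inhibition. Compound 3 gives the highest number of the three in this assay; one of its steps is a 1.6-fold higher number from compound 2 to compound 3 (0.20 log units; within the scatter), while the other is a 79-fold higher number from compound 1 to compound 3 (1.90 log units; beyond the scatter), so compound 3 is far weaker than compound 1 but sits level with compound 2.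

Compound 4, `Cc1ccc(S(=O)(=O)N(Cc2nnc(Cc3ccccc3Cl)o2)c2cccc(Cl)c2C)cc1`, differs from compound 3 in a single place: 2-chlorophenyl in place of 3-fluorophenyl on a saturated chain carbon bound to an aromatic carbon. Among the measured compounds shown here, two measured steps bear on it. The step from compound 1 to compound 3, a 79-fold higher number from compound 1 to compound 3 (1.90 log units; beyond the scatter), shows that swapping one group on this ring carbon for another can move the number a great deal. The step from compound 2 to compound 3, a 1.6-fold higher number from compound 2 to compound 3 (0.20 log units; within the scatter), shows that moving the same halogen around the ring hardly matters. For the measured compounds named here, the change here swaps one halogen for another and moves it at once; no measured pair covers that exact case, so a modest step is expected: a 1.1-fold lower number from compound 3 to compound 4 (0.02 log units; within the scatter). Compound 4 is therefore estimated at 300 nM in this assay, within a range from 100 nM to 1000 nM.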

Compound 4, half-maximal inhibitory concentration: 79.4 nM
For compound 4 the middle estimate is 3.8-fold (0.58 log units) above the measured one; measured number outside the range, below it.
By their numbers in this assay, from the lowest: compound 1; then compound 4; then compounds 2 and 3 (each within the scatter of the next).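

Rings carrying a halogen at this position are not interchangeable: a 4.0-fold lower number from compound 3 to compound 4 (0.60 log units; beyond the scatter) in this assay and a 2.5-fold lower number from compound 2 to compound 4 (0.40 log units; beyond the scatter) show that the 2-chlorophenyl group separates from both fluorophenyl groups, even though those two sit level with each other. That gain has limits, since a 20-fold higher number from compound 1 to compound 4 (1.30 log units; beyond the scatter) leaves the 4-ethoxyphenyl group of compound 1 well ahead of every halogenated ring shown. No measurement here explains why these changes have these effects.

The change to compound 4 alters the halogen and its place at once, so these compounds cannot tell which of the two matters; a 2-fluorophenyl or a 4-chlorophenyl group would separate them. On these data alone, it also remains open whether the ethoxy group itself is needed, or whether a methoxy group, a longer alkoxy chain or an amine on the ring would serve as well.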